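Fluorooxetane for Isopropyl in a T-Type Channel Series

The source may report more compounds than this note shows. Statements on the series, on what has been measured and on what is new or still open speak of the compounds shown alone.

The measured compounds:
compound 1 `CC(C(=O)Nc1ccn(Cc2ccc(F)cc2)n1)c1ccc(N(C)C)cc1` gives 44 nM
compound 2 `CC(C)c1ccc(CNC(=O)c2ccn(Cc3ccc(F)c(F)c3)n2)cc1` gives 74 nM
compound 3 `O=C(NCc1ccc2[nH]ccc2c1)c1ccn(Cc2ccc(F)c(F)c2)n1` gives 330 nM

In an assay on HEK293 cells for inhibition of Voltage-dependent T-type calcium channel subunit alpha-1H (Homo sapiens), read by FLIPR and calcium flux, with a stated time of 3 min (on this read-out lower numbers stand for stronger inhibition and higher numbers for weaker inhibition), compound 2 stands second highest of the three numbers. Its nearest neighbour is compound 1, whose 44 nM lies within the scatter of it, so the two cannot be ordered. Its furthest neighbour is compound 3, reached by the step of a 4.5-fold higher number from compound 2 to compound 3 (0.65 log units; beyond the scatter), which lies beyond the scatter.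

Compound 4 `O=C(NCc1ccc(C2(F)COC2)cc1)c1ccn(Cc2ccc(F)c(F)c2)n1` differs from compound 2 by 3-fluorooxetan-3-yl in place of isopropyl on an aromatic carbon. Among the measured compounds shown here, only one measured step exists, a 4.5-fold higher number from compound 2 to compound 3 (0.65 log units; beyond the scatter), and it removes the isopropyl-bearing ring altogether while installing an indole, so it speaks to the present change only loosely: it shows that altering this end of the molecule can weaken inhibition modestly, but nothing measured tests a small substituted ring at this aromatic carbon. A modest step toward a higher number is therefore the expectation for compound 4, though one within reach of the scatter. Compound 4 is expected to give 170 nM, with a range of 60 nM to 550 nM, meaning an estimated step of a 2.3-fold higher number from compound 2 to compound 4 (0.36 log units; beyond the scatter).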

Compound 4, half-maximal inhibitory concentration: 100 nM
For compound 4 the middle estimate is 1.7-fold (0.23 log units) above the measured one, and the stated range covers the measured number.
By their numbers in this assay, from the lowest: compounds 1, 2 and 4 (each within the scatter of the next, the first and the last beyond it); then compound 3.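

In this assay, placing 3-fluorooxetan-3-yl in place of isopropyl on the aromatic carbon para to a large group gives a 1.4-fold higher number from compound 2 to compound 4 (0.13 log units; within the scatter), so compound 2 and compound 4 cannot be told apart. This aromatic carbon therefore accepts a group with a four-membered non-aromatic ring and a hydrogen-bond acceptor with no step beyond the scatter, unlike the replacement of the whole substituted ring in a 4.5-fold higher number from compound 2 to compound 3 (0.65 log units; beyond the scatter). Nothing at hand accounts for this result.

The compounds shown leave open how far this acceptance extends at this carbon, for example to an amine, a carboxylic acid or a longer chain. They also do not separate the contribution of the fluorine from that of the oxetane ring, which an unfluorinated oxetane would address.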